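The source may report more compounds than this note shows. Statements on the series, on what has been measured and on what is new or still open speak of the compounds shown alone.

Measured in an ADME assay on MRC5 cells (Homo sapiens) for cytotoxicity, read by MTT assay, with a stated time of 72 h; a lower number here means that less compound is tolerated, a higher number that more compound is tolerated:
compound 1 `OC[C@H]1O[C@@H](n2cc(F)c3c(-c4ccoc4)ncnc32)[C@H](O)[C@@H]1O`: 15400 nM
compound 2 `OC[C@H]1O[C@@H](n2cc(F)c3c(-c4cccs4)ncnc32)[C@H](O)[C@@H]1O`: 47200 nM
compound 3 `OC[C@H]1O[C@@H](n2cc(F)c3c(-c4ccsc4)ncnc32)[C@H](O)[C@@H]1O`: 50000 nM

Compound 3 stands together with compound 2 at the better tolerated end of this small set. The gap between them, a 1.1-fold higher number from compound 2 to compound 3 (0.03 log units; within the scatter), gives no basis for ranking them. Compound 1 sits apart from both, as a 3.1-fold higher number from compound 1 to compound 2 (0.49 log units; beyond the scatter) and a 3.2-fold higher number from compound 1 to compound 3 (0.51 log units; beyond the scatter) show; each step is modest.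

The next compound is compound 4 `OC[C@H]1O[C@@H](n2cc(F)c3c(-c4ccc[nH]4)ncnc32)[C@H](O)[C@@H]1O`, which has 1H-pyrrol-2-yl in place of thiophen-3-yl on an aromatic carbon. For the measured compounds named here, no measured compound carries this ring, so the data offer no direct precedent. Going by the values given here, the closest guide is a 3.2-fold higher number from compound 1 to compound 3 (0.51 log units; beyond the scatter), the one measured step that changes the hetero atom at a fixed ring attachment. Moving the attachment within the thiophene, seen in a 1.1-fold higher number from compound 2 to compound 3 (0.03 log units; within the scatter), shifted nothing beyond the scatter. Among the compounds with values here, compound 1, the only measured compound whose ring lacks sulfur, gives 15400 nM, so a modest fall in this assay seems the likelier outcome on losing sulfur, though that rests on one comparison. The estimated change is a 2.5-fold lower number from compound 3 to compound 4 (0.40 log units; beyond the scatter). For compound 4 the expected value is 20000 nM, with an estimated range of 6000 nM to 60000 nM.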

Compound 4, half-maximal cytotoxic concentration: 44500 nM
Compound 4: the middle estimate sits 2.2-fold (0.35 log units) below what was measured, within the range that was stated.
By their numbers in this assay, from the lowest: compound 1; then compounds 4, 2 and 3 (each within the scatter of the next).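

At this position on the six-membered aromatic ring, 1H-pyrrol-2-yl stands level with both thiophenes in this assay (a 1.1-fold lower number from compound 3 to compound 4 (0.05 log units; within the scatter); a 1.1-fold lower number from compound 2 to compound 4 (0.03 log units; within the scatter)), so a ring without sulfur can match them, and exchanging the hydrogen-bond acceptor counted for thiophen-3-yl for the hydrogen-bond donor counted for 1H-pyrrol-2-yl moves the number by no more than the scatter. Compound 1 now stands apart from a second kind of ring as well (a 2.9-fold higher number from compound 1 to compound 4 (0.46 log units; beyond the scatter)), and since compound 4 also lacks sulfur, the absence of sulfur alone no longer marks out the lower number of compound 1. Nothing at hand accounts for why the furan-3-yl compound stands apart from the other three.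

The compounds shown leave open whether the point of attachment matters for furan or pyrrole, as each of these rings appears here with one attachment only. They also leave open how furan-2-yl, 1H-pyrrol-3-yl, a six-membered ring such as phenyl, or an amine on this same aromatic carbon would read in this assay.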